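The compounds below may be only part of what the source reports. "The series", "measured", "known", "first", "only" and "open" are said of these compounds alone.

Measured in a functional assay on MCF7 cells (Homo sapiens) for cytotoxicity; on this read-out higher numbers stand for weaker inhibition and lower numbers for stronger inhibition:
- compound 1 `C=C/C=C\[C@H](C)[C@H](OC(N)=O)[C@@H](C)[C@H](O)[C@@H](C)C/C(C)=C\[C@H](C)[C@@H](O)[C@@H](C)/C=C\CCc1cccc(Cl)c1` gives 650 nM
- compound 2 `C=C/C=C\[C@H](C)[C@H](OC(N)=O)[C@@H](C)[C@H](O)[C@@H](C)C/C(C)=C\[C@H](C)[C@@H](O)[C@@H](C)/C=C\CCc1cc(F)cc(F)c1` gives 2000 nM
- compound 3 `C=C/C=C\[C@H](C)[C@H](OC(N)=O)[C@@H](C)[C@H](O)[C@@H](C)C/C(C)=C\[C@H](C)[C@@H](O)[C@@H](C)/C=C\CCc1ccsc1` gives 4000 nM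

Compound 3 stands at the weak end of this set alongside compound 2. The data show a 2.0-fold higher number from compound 2 to compound 3 (0.30 log units; within the scatter), and also a 6.2-fold higher number from compound 1 to compound 3 (0.79 log units; beyond the scatter).

Compound 4 `C=C/C=C\[C@H](C)[C@H](OC(N)=O)[C@@H](C)[C@H](O)[C@@H](C)C/C(C)=C\[C@H](C)[C@@H](O)[C@@H](C)/C=C\CCc1cc(O)cc(O)c1` keeps the shared core and differs from compound 3 in one place: 3,5-dihydroxyphenyl in place of thiophen-3-yl on a saturated chain carbon, two bonds along the chain from a double-bonded chain carbon. The closest measured group is the 3,5-difluorophenyl of compound 2, and the nearest guide is a 2.0-fold higher number from compound 2 to compound 3 (0.30 log units; within the scatter). Swaps at this place have otherwise stayed modest, as in a 3.1-fold higher number from compound 1 to compound 2 (0.49 log units; beyond the scatter). No ring carrying hydroxyl groups has been measured, so the expectation is loose. In this assay the expected result is no step beyond the scatter, a 1.3-fold lower number from compound 3 to compound 4 (0.12 log units; within the scatter). Compound 4 is estimated at 3000 nM, with an expected range of 900 nM to 10000 nM.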

Compound 4, half-maximal inhibitory concentration: > 1000 nM
Compound 4 gave a limit, no number; the forecaster's own chance of this, stated with the estimate: 15%; the middle value is on the limit's open side.
By their numbers in this assay, from the lowest: compound 1; then compounds 2 and 3 (each within the scatter of the next).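

In this assay, going by these compounds alone, compound 4, the one compound here whose ring carries hydroxyl groups, gives only a limit, not a number: the limit of > 1000 nM in this assay, at which 1 of the 4 values shown sits. Within the data shown here, the one readable comparison is an at least 1.5-fold higher number from compound 1 to compound 4 (0.18 log units; that floor lies within the scatter), so 3,5-dihydroxyphenyl is not clearly separated from 3-chlorophenyl, and the steps from compound 2 and from compound 3 cannot be read.

As far as these compounds go, how far compound 4 lies past its limit stays open, and so does its standing against 3,5-difluorophenyl and thiophen-3-yl. Also open, from the compounds shown here alone, is how a ring bearing an amine or a carboxylic acid would read at this place.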